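The source may hold more compounds than are shown below. What is called first, only, known or untested is meant among the compounds shown, and "the series" means these compounds.

Working notes on the series.

The shared core is that of compound 1 `CC(C)=CCC[C@H](C)c1ccc(C)cc1O`. In an ADME assay on MDA-MB-231 cells (Homo sapiens) for inhibition, read by MTT assay, with a stated time of 24 h (a higher number here means a weaker inhibitor, a lower number a stronger inhibitor), compound 1 gives > 20000 nM, which is a limit of the assay and not a number. Among the measured compounds shown here, compound 2 `CC(C)=CCC[C@H](C)c1ccc(C)c2c1OCN(CC1CCNCC1)C2` is the only other measured member of the set. In this assay compound 2 gives > 20000 nM, again a limit and not a number. For the measured compounds named here, compound 1 therefore stands at the limit of > 20000 nM in this assay, at which 2 of the 2 values shown sit; the two measured values do not separate from each other, and no step between measured compounds can be sized here.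

Compound 3 `CC(C)=CCC[C@H](C)c1ccc(C)c(CNCCCCCO)c1O` has not yet been measured in this assay. It differs from compound 1 by ((5-hydroxypentyl)amino)methyl in place of hydrogen on an aromatic carbon. Going by the values given here, with both measured values resting on a limit, there is no measured step on which to lean, and the working expectation is a step of no more than the scatter in either direction. Compound 3 is expected to give about 20000 nM in this assay, with a plausible range from 5000 nM to 60000 nM. The expected step is a number no higher from compound 1 to compound 3 (the limit leaves the size open), and a renewed report of only a limit remains the likelier outcome.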

Compound 3, half-maximal inhibitory concentration: > 20000 nM
Compound 3 ended at the assay's limit; the forecaster's own chance of this, stated with the estimate: 65%; the middle value sits exactly at the limit.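

No step can be read from compound 1 to compound 3, since both rest on a limit of the assay and not on a number: the limit of > 20000 nM in this assay, at which 3 of the 3 values shown sit. The compounds shown leave open whether any change to the core of compound 1 gives a measurable value in this assay, and how large the step for ((5-hydroxypentyl)amino)methyl in place of hydrogen is.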